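A few compounds are considered here, and "the series" means these few. Any claim that something is new, unique, unknown or untested is made for them only; others in the source may bear on it.

Measured compounds in an ADME assay on microsomes from liver (Homo sapiens) for metabolic stability; on this read-out higher numbers stand for fast clearance and lower numbers for slow clearance:
Compound 1, `CN(C)C(=O)CN1CCC(c2cc3c(-c4ccc(=O)n(C5CCC5)c4)ccnc3[nH]2)CC1`: < 3 uL/min
Compound 2, `CN(C)C(=O)CN1CCC(c2cc3c(-c4ccc(=O)n(C5CCOCC5)c4)ccnc3[nH]2)CC1`: 8.2 uL/min
Compound 3, `CC(C)n1cc(-c2ccnc3[nH]c(C4CCN(CC(=O)N5CCCC5)CC4)cc23)ccc1=O`: 45 uL/min

The value of compound 1 is a limit of the assay, not a number. Among the two numbers, compound 3 stands highest; compound 2 gives the nearer number, and the gap between these two is beyond the scatter. Among the measured compounds shown here, the one measured step, an at least 2.7-fold higher number from compound 1 to compound 2 (0.43 log units; beyond the scatter), concerns a change on the aromatic nitrogen and is at least modest in size.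

Compound 4, `CC(C)n1cc(-c2ccnc3[nH]c(C4CCN(CC(=O)N(C)C)CC4)cc23)ccc1=O`, differs from compound 3 by dimethylamino in place of pyrrolidin-1-yl on a carbonyl carbon. For the measured compounds named here, no measured step concerns this change: compounds 1 and 2 carry the dimethylcarbamoyl side chain, compound 3 the (pyrrolidin-1-yl)carbonyl one, but each pair also differs on the aromatic nitrogen, so the effect of the side chain alone cannot be read from the numbers. The expected step is a 1.5-fold lower number from compound 3 to compound 4 (0.18 log units; within the scatter), a small drop that need not exceed the scatter. Compound 4 is therefore expected to give 30 uL/min in this assay, within a range from 12 uL/min to 70 uL/min.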

Compound 4, intrinsic clearance in a liver preparation (reported as CLH), per the amount of preparation that the assay uses: < 3 uL/min
Compound 4: only a limit was reported; the forecaster's own chance of this, stated with the estimate: 5%; middle value at least 10-fold (1.00 log units) from the limit.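

In this assay compound 4 gives < 3 uL/min, which is a limit of the assay and not a number. Among the compounds shown here, the change on the carbonyl carbon, which no earlier pair isolated, now has a measured effect: dimethylamino in place of pyrrolidin-1-yl gives an at least 15-fold lower number from compound 3 to compound 4 (1.17 log units; beyond the scatter), and isopropyl in place of oxan-4-yl on the aromatic nitrogen gives an at least 2.7-fold lower number from compound 2 to compound 4 (0.43 log units; beyond the scatter). Both steps are bounded on one side only, and the step involving compound 1 cannot be read, because two compounds sit at the same floor: the limit of < 3 uL/min in this assay, at which 2 of the 4 values shown sit.

From the compounds shown here alone, whether piperidin-1-yl or morpholin-4-yl on the carbonyl carbon would behave like pyrrolidin-1-yl or like dimethylamino stays open. Going by these compounds, it is also open whether the step from pyrrolidin-1-yl to dimethylamino would recur with cyclobutyl or oxan-4-yl on the aromatic nitrogen.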